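Methyl in place of a second dichloroacetamide on compound 1

The source may report more compounds than this note shows. Statements on the series, on what has been measured and on what is new or still open speak of the compounds shown alone.

Three compounds of the series are measured in a functional assay on NCI-H460 cells (Homo sapiens) for cytotoxicity, read by MTT assay, with a stated time of 68 h; on this read-out higher numbers stand for weaker inhibition and lower numbers for stronger inhibition. Compound 1 `O=C(Nc1cccc(-c2cccc(NC(=O)C(Cl)Cl)c2)c1)C(Cl)Cl` returns only a limit: in this assay compound 1 is reported as > 50000 nM, which is the limit of > 50000 nM in this assay, at which 1 of the 3 values shown sits, so no number is known for it. Compound 2 `CCOc1cccc(-c2cc(NC(=O)C(Cl)Cl)cc(-c3cccc(OCC)c3)c2)c1` gives 4950 nM in this assay. Compound 3 `Cc1ccccc1-c1cccc(NC(=O)C(Cl)Cl)c1` gives 31600 nM in this assay. Going by the values given here, no two of these three differ in a single place, so no single step is on record; the values show only that compound 2 and compound 3 return numbers while compound 1 does not.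

Compound 4 `Cc1cccc(-c2cccc(NC(=O)C(Cl)Cl)c2)c1` is not yet measured. It differs from compound 1 by methyl in place of ((dichloromethyl)carbonyl)amino on an aromatic carbon. Compound 3 likewise pairs one methyl with one dichloroacetamide on the shared core and returns 31600 nM, which is the nearest point of reference. Compound 4 is therefore expected to fall in the same region, and the step of an at least 1.6-fold lower number from compound 1 to compound 4 (0.22 log units; that floor lies within the scatter) is expected to run toward lower numbers, though since compound 1 is only a limit its true size cannot be fixed. For compound 4 the estimate in this assay is 30000 nM, with a range from 10000 nM to 100000 nM.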

Compound 4, half-maximal inhibitory concentration: 24300 nM
Compound 4: the middle estimate sits 1.2-fold (0.09 log units) above what was measured; measured number inside the range.
By their numbers in this assay, from the lowest: compound 2; then compounds 4 and 3 (each within the scatter of the next). At a limit, above all of these: compound 1.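

In this assay, going by these compounds alone, methyl in place of ((dichloromethyl)carbonyl)amino on an aromatic carbon, meta to a large group, gives the first single-place step: an at least 2.0-fold lower number from compound 1 to compound 4 (0.31 log units; beyond the scatter). A second ((dichloromethyl)carbonyl)amino at this position is therefore not required for a measured number in this assay, and the single remaining ((dichloromethyl)carbonyl)amino of compound 4 is enough to return one. Compound 1 stands at a limit, so this step is only a floor and its true size stays unknown: the limit of > 50000 nM in this assay, at which 1 of the 4 values shown sits.

As far as these compounds go, the step carries a loss and a gain at once, so it remains open whether the lower number follows from the departure of ((dichloromethyl)carbonyl)amino, from the arrival of methyl, or from both. Also open, from the compounds shown here alone, is how an amine, a carboxylic acid or a longer chain on this same aromatic carbon would read in this assay, and whether any of them would shift the number beyond the scatter relative to compound 4.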